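Ring-nitrogen repositioning in the bicyclic ether of compound 2

The compounds below may be only part of what the source reports. "The series", "measured", "known", "first", "only" and "open" are said of these compounds alone.

Of the compounds shown here, two have been measured in an in vitro assay on Sf9 cells for inhibition of leukotriene A-4 hydrolase (Homo sapiens), read by immunoassay, with stated times of 10 min and 30 min; a higher number here means a weaker inhibitor, a lower number a stronger inhibitor. Compound 1 `O=C(O)C1CCN(Cc2coc3cc(Oc4nc5ncccc5s4)ccc23)CC1` gives 8.3 nM in this assay. Compound 2 `CC(=O)N1CC2CC1CN2Cc1cc2ccc(Oc3nc4ncccc4s3)cc2o1` gives 62 nM in this assay and stands at the higher of the two numbers, with compound 1 at a lower number that lies beyond the usual scatter. The unmeasured compound 3 `CC(=O)N1CC2CC1CN2Cc1cc2ccc(Oc3nc4cnccc4s3)cc2o1` differs from compound 2 by a group of 9 heavy atoms (6 carbon, 2 nitrogen, 1 sulfur; one five-membered aromatic ring with 2 hetero atoms, one six-membered aromatic ring with 1 hetero atom) in place of a group of 9 heavy atoms (6 carbon, 2 nitrogen, 1 sulfur; one five-membered aromatic ring with 2 hetero atoms, one six-membered aromatic ring with 1 hetero atom), on an oxygen on an aromatic ring; the two have the same atoms, joined differently, so the change is a rearrangement of the bicyclic ether group rather than an addition or a removal. Within the data shown here, no step between measured compounds bears on such a rearrangement, so the expectation rests on compound 2 alone. The step of a 1.3-fold higher number from compound 2 to compound 3 (0.11 log units; within the scatter) is expected to be small, within the usual scatter, with no clear direction. Compound 3 is estimated at 80 nM in this assay, with a range from 25 nM to 300 nM.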

Compound 3, half-maximal inhibitory concentration: 2370 nM
Beside the measured number, compound 3's estimate is 30-fold (1.47 log units) below it; measured number above the stated range.
By their numbers in this assay, from the lowest: compound 1; then compound 2; then compound 3.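

In this assay, among these compounds, the earlier compounds gave no reading on the group on an oxygen on an aromatic ring, and the rearrangement now shows that this position tolerates no free repositioning of the ring nitrogen: the result is a 38-fold higher number from compound 2 to compound 3 (1.58 log units; beyond the scatter), a large loss. The leaving and entering groups have the same heavy atoms, ring types, hydrogen-bond donor and acceptor counts and net charge, so none of these counted features separates them, and only the way the atoms are joined differs. Nothing at hand bears on the origin of this step.

From the compounds shown here alone, whether the same rearrangement costs a similar amount on the side chain of compound 1 remains open. Also open, going by these compounds, is whether an amine or a methoxy group on the rearranged bicyclic ether would restore the number of compound 2.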